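This account rests on a few compounds, and the source may have more. Where it says the series, first, only, none or still open, it means among the compounds named here.

Measured compounds in an assay on CHO-K1 cells for displacement of a labelled ligand from adenosine receptor A1 (Homo sapiens), tested at 10 uM; on this read-out higher numbers stand for more inhibition at the one concentration tested (going by the name of the read-out) and lower numbers for less inhibition:
- compound 1 `CC(=O)c1ccc(-c2sc(N)c(C(=O)c3ccccc3)c2-c2cccc(C(F)(F)F)c2)cc1`: 25.6%
- compound 2 `Nc1sc(-c2ccc([N+](=O)[O-])cc2)c(-c2cccc(C(F)(F)F)c2)c1C(=O)c1ccccc1`: 34.8%
- compound 3 `CCOC(=O)c1c(N)sc(-c2ccc(C(C)=O)cc2)c1-c1cccc(C(F)(F)F)c1`: 64.6%

Compound 4 `CCOC(=O)c1c(N)sc(-c2ccc([N+](=O)[O-])cc2)c1-c1cccc(C(F)(F)F)c1` has not yet been measured in this assay.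

Two changes are in play. From compound 1 to compound 3 the change is ethoxy in place of phenyl on a carbonyl carbon, and on this assay it brought a number 39 percentage points higher from compound 1 to compound 3 (beyond the scatter). Compound 3 thus sits highest of the three, and both its steps to the others are beyond the scatter.

The change from compound 1 to compound 2 is nitro in place of acetyl on an aromatic carbon; it gave a number 9.2 percentage points higher from compound 1 to compound 2 (within the scatter). The same change is applied from compound 3 to compound 4, (nitro in place of acetyl on an aromatic carbon), on the same place, the two cores differing only as told by ethoxy in place of phenyl on a carbonyl carbon. Among the compounds with values here, nothing in the data shows how the two changes interact, so the one measured step is the only guide.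

For compound 4 the expected step is a number 5.4 percentage points higher from compound 3 to compound 4 (within the scatter), resting on the small step seen between compound 1 and compound 2, a number 9.2 percentage points higher from compound 1 to compound 2 (within the scatter), carried over to the higher base of compound 3. Compound 4 is therefore estimated at 70%, with a range from 50% to 88%.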

Compound 4, a percentage reported as inhibition, at one concentration (the size of the read-out at that concentration, not a potency): 71.4%
The estimate for compound 4 lay 1.4 percentage points below the measured number, and the stated range covers the measured number.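

In this assay, the change from 4-acetylphenyl to 4-nitrophenyl gives a number 6.8 percentage points higher from compound 3 to compound 4 (within the scatter), and the two cores agree on this step: the same change on two cores in this assay, a number 9.2 percentage points higher (within the scatter) from compound 1 to compound 2 and a number 6.8 percentage points higher (within the scatter) from compound 3 to compound 4, 2.4 percentage points apart, within the scatter of two such steps. The change to ethoxy in place of phenyl on the carbonyl carbon gives a number 36.6 percentage points higher from compound 2 to compound 4 (beyond the scatter), and it also carries over from one core to the other: the same change on two cores in this assay, a number 39 percentage points higher (beyond the scatter) from compound 1 to compound 3 and a number 36.6 percentage points higher (beyond the scatter) from compound 2 to compound 4, 2.4 percentage points apart, within the scatter of two such steps. Within this set of four compounds the two changes therefore add up with no sign of interaction, but one pair of cores does not establish a rule for the series, and since the nitro step stays within the scatter on both cores, it does not show that nitro in place of acetyl shifts the read-out at all.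

Open, going by these compounds, is whether this agreement holds for other groups at the same place on the ring, such as an amine, a nitrile or a carboxylic acid, and whether a longer chain in place of ethoxy behaves as ethoxy does. On these data alone, each number also comes from a single concentration, so potency remains open.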